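A few compounds are considered here, and "the series" means these few. Any claim that something is new, unique, unknown or untested is made for them only; others in the source may bear on it.

Measured so far in a functional assay on Caco-2 cells (Homo sapiens) for inhibition, read by MTT assay, with a stated time of 48 h, tested at 10 uM; a lower number here means less inhibition of growth, a higher number more inhibition of growth at the concentration tested:
- compound 1 `Cc1cc(=O)c2c(O)c(CN3CCCC3CO)c(O)c([C@H]3CCN(C)C[C@H]3O)c2o1`: 19%
- compound 2 `Cc1cc(=O)c2c(O)c(CN3CCC(c4ccccc4)CC3)c(O)c([C@H]3CCN(C)C[C@H]3O)c2o1`: 21%
- compound 3 `Cc1oc2c([C@H]3CCN(C)C[C@H]3O)c(O)cc(O)c2c(=O)c1C(O)c1ccc(Cl)cc1`: 3%

Compound 3 stands lowest of the three, beyond the scatter from both compound 1 and compound 2. Those two carry a different side chain on the shared core, so they say little about the aryl group in compound 3.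

Compound 4 `COc1ccc(C(O)c2c(C)oc3c([C@H]4CCN(C)C[C@H]4O)c(O)cc(O)c3c2=O)cc1Br` is the next to be read. The change from compound 3 is 3-bromo-4-methoxyphenyl in place of 4-chlorophenyl on a saturated chain carbon bound to an aromatic carbon and an oxygen on a saturated carbon, so (4-chlorophenyl)(hydroxy)methyl becomes (3-bromo-4-methoxyphenyl)(hydroxy)methyl. For the measured compounds named here, no measured pair shows a step of this kind, so the expectation rests on compound 3 at 3% as the closest reference, with all three readings in this assay being modest. The expected change is small and upward, and it is not expected to go beyond the scatter: the estimated step is a number 4 percentage points higher from compound 3 to compound 4 (within the scatter). For compound 4 the estimated value is 7%, with an expected range of 0% to 19%.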

Compound 4, percent growth inhibition at one concentration: 0%
The estimate for compound 4 lay 7 percentage points above the measured number; the measured number falls inside the stated range.
By their numbers in this assay, from the lowest: compounds 4 and 3 (each within the scatter of the next); then compounds 1 and 2 (each within the scatter of the next).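

In this assay, putting 3-bromo-4-methoxyphenyl in place of 4-chlorophenyl on a saturated chain carbon bound to an aromatic carbon and an oxygen on a saturated carbon gives a number 3 percentage points lower from compound 3 to compound 4 (within the scatter), so this exchange does not separate the two compounds. The entering group holds 9 heavy atoms and 1 hydrogen-bond acceptor against 7 and 0 in the leaving group, and this difference brings no shift beyond the scatter. No measured information on the series accounts for this result.

From the compounds shown here alone, whether an amine, a carboxylic acid or a longer alkyl chain in place of the aryl group at this carbon would change the reading remains open. Going by these compounds, the hydroxy group on this chain carbon is present in both compounds, so its contribution also remains open.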